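Acetylating the Second Hydroxyl of a Diarylheptanoid Diol

The source may hold more compounds than are shown below. What is called first, only, known or untested is meant among the compounds shown, and "the series" means these compounds.

This study concerns four compounds built on a shared chain that carries two phenol-bearing arms and two oxygen-bearing positions along its saturated backbone. Compound 2, `Oc1ccc(CC[C@@H](O)C[C@H](O)CCc2ccc(O)cc2)cc1`, carries a hydrogen on both of those oxygens. In a functional assay on RAW264.7 cells (Mus musculus) for inhibition, read by spectrophotometry and Griess assay, with a stated time of 24 h (a lower number here means a stronger inhibitor, a higher number a weaker inhibitor), compound 2 gives > 100000 nM, which is a limit of the assay and not a number. Compound 1, `CC(=O)O[C@H](CCc1ccc(O)cc1)C[C@H](O)CCc1ccc(O)cc1`, differs from compound 2 by one change: acetyl in place of hydrogen on an oxygen on a saturated carbon. In this assay compound 1 gives 32000 nM. That single change made an at least 3.1-fold lower number from compound 2 to compound 1 (0.49 log units; beyond the scatter), a step that rests on (the limit of > 100000 nM in this assay, at which 1 of the 3 values shown sits).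

Compound 3, `CC(=O)O[C@H](CCc1ccc(O)c(O)c1)C[C@H](O)CCc1ccc(O)c(O)c1`, carries the same acetyl on one oxygen but has a different pair of aromatic arms; the difference between the cores of compound 3 and compound 2 is not broken down here. In this assay compound 3 gives 35500 nM, which sits within the scatter of compound 1.

Compound 4, `CC(=O)O[C@H](CCc1ccc(O)c(O)c1)C[C@@H](CCc1ccc(O)c(O)c1)OC(C)=O`, is not yet measured. It differs from compound 3 by acetyl in place of hydrogen on an oxygen on a saturated carbon, the same change that led from compound 2 to compound 1, at the same kind of place. Because that earlier change gave an at least 3.1-fold lower number from compound 2 to compound 1 (0.49 log units; beyond the scatter), a lowering of similar order is expected here, with caution since the earlier step starts from a limit. The estimated step is a 2.5-fold lower number from compound 3 to compound 4 (0.40 log units; beyond the scatter) for compound 4. In this assay compound 4 is expected to give about 14000 nM, most likely between 5000 nM and 40000 nM.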

Compound 4, half-maximal inhibitory concentration: 7980 nM
Compound 4: the middle estimate sits 1.8-fold (0.24 log units) above what was measured; the range from low to high includes it.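

In this assay, replacing hydroxy with acetoxy on the remaining free oxygen on a saturated carbon gave a 4.4-fold lower number from compound 3 to compound 4 (0.65 log units; beyond the scatter), so compound 4 has two acetyl groups where compound 3 has one. The same change lowered the number on both cores shown, which means its direction carried over from one core to the other, although two cores are too few to establish a general rule, and the comparison of the two steps reads: the same change on two cores in this assay, an at least 3.1-fold lower number (0.49 log units; beyond the scatter) from compound 2 to compound 1 and a 4.4-fold lower number (0.65 log units; beyond the scatter) from compound 3 to compound 4; the limit leaves it open whether they differ. Compound 2, where the earlier step begins, gives > 100000 nM, which is a limit of the assay and not a number, so the data do not show whether the size of the step carries over as well: the limit of > 100000 nM in this assay, at which 1 of the 4 values shown sits.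

The compounds shown leave open whether adding a second acetyl to compound 1, on the core with one hydroxy group on each aromatic arm, would lower the number by a similar amount. They also leave open whether a longer chain in the ester, or an amine in place of the acetoxy group at this oxygen-bearing position, would give a lower or higher number than acetyl does.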